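The source may hold more compounds than are shown below. What is called first, only, known or untested is meant among the compounds shown, and "the series" means these compounds.

Among the measured compounds shown here, compound 1 `O=C(c1cccc(Cl)c1)N1CCC(NS(=O)(=O)c2cc(S(=O)(=O)c3ccccc3)ccc2C(F)(F)F)CC1` gives 870 nM in an assay on U2OS cells for inhibition of secreted frizzled-related protein 1 (Homo sapiens), read by a luciferase reporter, with a stated time of 18 h (on this read-out lower numbers stand for an effect already at smaller amounts and higher numbers for an effect only at larger amounts of compound), and stands highest of the two numbers measured; compound 2 `O=C(c1ccc(Cl)nc1)N1CCC(NS(=O)(=O)c2cc(S(=O)(=O)c3ccccc3)ccc2C(F)(F)F)CC1` gives 140 nM in this assay, and the only measured step is a 6.2-fold lower number from compound 1 to compound 2 (0.79 log units; beyond the scatter). Compound 3 `O=C(O)c1cccc(S(=O)(=O)N2CCC(NS(=O)(=O)c3cc(S(=O)(=O)c4ccccc4)ccc3C(F)(F)F)CC2)c1` is not yet measured. It differs from compound 1 in one place: (3-carboxyphenyl)sulfonyl in place of (3-chlorophenyl)carbonyl on an amine nitrogen in a ring. For the measured compounds named here, the step from compound 1 to compound 2 concerns a different position, the ring on the carbonyl carbon, and so bears only loosely on the change to compound 3; no measured pair varies the group on the amine nitrogen in a ring. The size and direction of the step to compound 3 are therefore open, and the estimate rests on compound 1 alone with a wide range. Compound 3 is expected to give about 1000 nM in this assay, between 200 nM and 5000 nM. The expected step of a 1.1-fold higher number from compound 1 to compound 3 (0.06 log units; within the scatter) is thus close to none beyond the scatter, with the range carrying the uncertainty.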

Compound 3, half-maximal effective concentration: 190 nM
Estimate against measurement, compound 3: 5.3-fold (0.72 log units) above, and the stated range ends above it.
By their numbers in this assay, from the lowest: compounds 2 and 3 (each within the scatter of the next); then compound 1.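

On the amine nitrogen in a ring, the position takes a far larger change than the earlier pair showed: (3-carboxyphenyl)sulfonyl in place of (3-chlorophenyl)carbonyl in this assay gives a 4.6-fold lower number from compound 1 to compound 3 (0.66 log units; beyond the scatter), so the number falls rather than rises even though the carbonyl and the chlorine are both gone. Set against the (6-chloropyridin-3-yl)carbonyl group, the same change gives a 1.4-fold higher number from compound 2 to compound 3 (0.13 log units; within the scatter), which leaves compound 2 and compound 3 indistinguishable here, with two quite different groups on this nitrogen each standing beyond the scatter from compound 1. No measurement on these compounds accounts for either step.

The sulfonyl and the carboxylic acid enter together, so their shares in the step stay unseparated; a (3-chlorophenyl)sulfonyl or a (3-carboxyphenyl)carbonyl group would divide them. As far as these compounds go, whether an amide or a nitrile in place of the carboxylic acid holds the value also remains open.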